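The source may hold more compounds than are shown below. What is called first, only, known or untested is meant among the compounds shown, and "the series" means these compounds.

Compound 1 `COc1ccc(/C=C2\CCC/C(=C\c3ccc(Cl)cc3)C2=O)cc1OC`: 10100 nM
Compound 2 `COc1ccc(/C=C2\CCC/C(=C\c3cccc(Br)c3)C2=O)cc1OC`: 12800 nM

Both compounds were run in a functional assay on A549 cells (Homo sapiens) for cytotoxicity, read by MTT assay, with a stated time of 72 h; a higher number here means a weaker inhibitor, a lower number a stronger inhibitor. Among the compounds with values here, compound 2 has the higher of the two numbers, but its only neighbour is compound 1, and the step of a 1.3-fold higher number from compound 1 to compound 2 (0.10 log units; within the scatter) stays within the scatter, so the two cannot be ordered. Compound 3 `COc1cccc(/C=C2\CCC/C(=C\c3ccc(OC)c(OC)c3)C2=O)c1` is not yet measured. It differs from compound 2 by methoxy in place of bromo on an aromatic carbon. Within the data shown here, no measured step exchanges a bromo for a methoxy; the single step on record, a 1.3-fold higher number from compound 1 to compound 2 (0.10 log units; within the scatter), swaps one halogen for another and stays within the scatter, which gives no footing for a direction. The expected step is therefore small, a 1.1-fold higher number from compound 2 to compound 3 (0.04 log units; within the scatter), and the estimate for compound 3 in this assay is 14000 nM, expected to fall between 6000 nM and 33000 nM.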

Compound 3, half-maximal inhibitory concentration: 6700 nM
The estimate for compound 3 lay 2.1-fold (0.32 log units) above the measured number; measured number inside the range.
By their numbers in this assay, from the lowest: compounds 3, 1 and 2 (each within the scatter of the next).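

In this assay, within the data shown here, the step of a 1.9-fold lower number from compound 2 to compound 3 (0.28 log units; within the scatter) is the first on record to replace a halogen on this aromatic carbon with a group that is not a halogen, one that brings a hydrogen-bond acceptor and one more heavy atom, and the number stays within the scatter. The step of a 1.5-fold lower number from compound 1 to compound 3 (0.18 log units; within the scatter) also stays within the scatter, so the 3-methoxyphenyl, 3-bromophenyl and 4-chlorophenyl groups cannot be ordered here, and all three compounds remain in one band of values. No measurement at hand accounts for these numbers or speaks to any difference between these groups.

From the compounds shown here alone, it remains open whether an amine or a carboxylic acid on this aromatic carbon would give a step beyond the scatter. The same holds for a longer chain such as ethoxy in place of the methoxy of compound 3.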